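The source may report more compounds than this note shows. Statements on the series, on what has been measured and on what is new or still open speak of the compounds shown alone.

Compound 1 `CCCCCCNC(=O)n1cc(C(F)(F)F)c(=O)[nH]c1=O` gives 12 nM in an assay on HEK293 cells for inhibition of acid ceramidase (Rattus norvegicus), read by LC-MS, with a stated time of 30 min; a lower number here means a stronger inhibitor, a higher number a weaker inhibitor. Compound 2 `CCCCCCNC(=O)n1cc(CC)c(=O)[nH]c1=O` gives 733 nM, the highest of the two numbers measured, reached by the step of a 61-fold higher number from compound 1 to compound 2 (1.79 log units; beyond the scatter), which was large. Compound 3 `CCCCCCNC(=O)n1cc(OC)c(=O)[nH]c1=O` carries the change (methoxy in place of ethyl on an aromatic carbon), a swap that keeps two heavy atoms but brings in one hydrogen-bond acceptor. Going by the values given here, no measured step covers an ethyl-to-methoxy exchange, so the only guide is that changing this group moved the number strongly before. The expected step of a 2.0-fold higher number from compound 2 to compound 3 (0.31 log units; beyond the scatter) is modest, and compound 3 is estimated at 1500 nM, within 300 nM to 7000 nM.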

Compound 3, half-maximal inhibitory concentration: 1100 nM
Beside the measured number, compound 3's estimate is 1.4-fold (0.13 log units) above it; low and high end bracket the measured number.
By their numbers in this assay, from the lowest: compound 1; then compounds 2 and 3 (each within the scatter of the next).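

In this assay, methoxy in place of ethyl on this aromatic carbon gives a 1.5-fold higher number from compound 2 to compound 3 (0.18 log units; within the scatter), so adding a hydrogen-bond acceptor while keeping two heavy atoms makes no readable difference here. Methoxy in place of trifluoromethyl gives a 92-fold higher number from compound 1 to compound 3 (1.96 log units; beyond the scatter), a large step, so of these three groups only trifluoromethyl goes with the low number. Nothing measured here explains why trifluoromethyl stands apart from the other two. Still open, as far as these compounds go, is whether a chlorine atom or a nitrile at this position would give a number close to that of compound 1 or close to those of compound 2 and compound 3.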